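The source may hold more compounds than are shown below. What is called first, only, known or untested is meant among the compounds shown, and "the series" means these compounds.

Compound 1 `O=S(=O)(c1cccc(Nc2nc(-c3cncnc3)nc3cccc(-c4ccccc4)c23)c1)N1CCOCC1`: > 99.5%
Compound 2 `NC(=O)c1ccc(-c2cccc3nc(-c4cncnc4)nc(NCc4ccccn4)c23)cc1`: > 99%
Compound 3 `NS(=O)(=O)c1ccc(-c2nc(NCc3ccccn3)c3c(-c4ccccc4)cccc3n2)cn1`: > 99.5%

These three compounds were tested in an ADME assay on a cell-free system (plasma, Rattus norvegicus) for protein binding. None of them received an exact number, and the results so far consist only of limits: the limit of > 99% in this assay, at which 1 of the 3 values shown sits, and (the limit of > 99.5% in this assay, at which 2 of the 3 values shown sit).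

Compound 3 gives > 99.5%, which is a limit of the assay and not a number.

Compound 4 `CS(=O)(=O)Nc1cncc(-c2nc(NCc3ccccn3)c3c(-c4ccccc4)cccc3n2)c1` keeps the rest of compound 3 and carries 5-(methanesulfonamido)pyridin-3-yl in place of 6-sulfamoylpyridin-3-yl on an aromatic carbon. The swap sits on the six-membered aromatic ring with 2 nitrogen, between two ring nitrogen atoms.

For the measured compounds named here, no pair of measured compounds differs in just one place, so the data offer no direct guide to the size of this step. All three measured compounds, despite their different groups, are reported only as limits in this assay. On that basis, no step beyond the usual scatter is expected, and no direction can be favoured. The expected step is an at least 1.2-fold higher unbound fraction from compound 3 to compound 4 (0.07 log units; that floor lies within the scatter).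

The estimated value for compound 4 is 99.4%, with an expected range from 98.5% to 99.9%.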

Compound 4, plasma protein binding: > 99.5%
Compound 4 ended at the assay's limit (the forecaster's own chance of this, stated with the estimate: 75%); at least 1.2-fold (0.07 log units) (unbound fraction) between middle value and limit.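

In this assay, for the compounds shown here, compound 3 and compound 4 both sit at the limit of the assay, so no step between them can be read. The compounds shown leave open how much of either compound is actually free, and whether 5-(methanesulfonamido)pyridin-3-yl in place of 6-sulfamoylpyridin-3-yl changes that amount at all.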